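The compounds below may be only part of what the source reports. "The series", "measured", "known", "first", "only" and "open" are said of these compounds alone.

Compound 1 `Cc1nc(-c2ccc(C(F)(F)F)cc2)sc1CNc1ccc(C(=O)O)cc1` stands lowest of the three measured compounds in a functional assay on CHO cells for agonist activity at Free fatty acid receptor 1 (Homo sapiens), read by a luciferase reporter (a higher number here means a larger maximal response, a lower number a smaller maximal response), giving 10%. Compound 2 `CC(CC(=O)O)c1ccc(NCc2cccc(Oc3ccccc3)c2)cc1` gives 83% in this assay, and compound 3 `CC(C)NC(=O)CCc1ccc(NCc2cccc(Oc3ccccc3)c2)cc1` gives 66%. Within the data shown here, the one measured step that bears here, a number 17 percentage points lower from compound 2 to compound 3 (beyond the scatter), is the same trade of an acid for an amide but on a different core and with a different acid side chain. Compound 4 `Cc1nc(-c2ccc(C(F)(F)F)cc2)sc1CNc1ccc(CCC(=O)NC(C)C)cc1` differs from compound 1 by 2-(isopropylcarbamoyl)ethyl in place of carboxy on an aromatic carbon. Among the measured compounds shown here, with compound 1 already so low, that downward step cannot repeat in full, and no measured pair shows how the core of compound 1 responds to this change. For compound 4 the expectation is 15% with a range of 3% to 45%, so the expected step is a number 5 percentage points higher from compound 1 to compound 4 (within the scatter), within the scatter.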

Compound 4, largest response reached (reported as percent of maximum), in percent of the reference or control that the assay uses: 84%
Estimate against measurement, compound 4: 69 percentage points below, and the stated range ends below it.
By their numbers in this assay, from the lowest: compound 1; then compound 3; then compounds 2 and 4 (each within the scatter of the next).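

In this assay, placing 2-(isopropylcarbamoyl)ethyl in place of carboxy, para to a large group, gives a number 74 percentage points higher from compound 1 to compound 4 (beyond the scatter). The earlier amide step, a number 17 percentage points lower from compound 2 to compound 3 (beyond the scatter), runs the other way, so its direction does not carry over to the core of compound 1. Nothing available explains this reversal or the size of the rise.

The chain and the isopropyl amide enter together, and their shares in the rise remain unseparated. A 2-carboxyethyl group on the core of compound 1 would divide the two.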